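Replacing (furan-3-yl)methyl with (4-methoxyphenyl)amino

A few compounds are considered here, and "the series" means these few. Any claim that something is new, unique, unknown or untested is made for them only; others in the source may bear on it.

Compound 1 `Cc1cc(Cc2ccc(C(F)(F)F)cc2)c(=O)n(CC(=O)Nc2ccc(Br)cc2)n1`: > 50000 nM
Compound 2 `Cc1cc(Cc2ccoc2)c(=O)n(CC(=O)Nc2ccc(Br)cc2)n1`: > 50000 nM
Compound 3 `Cc1cc(Cc2ccc(C(N)=O)cc2)c(=O)n(CC(=O)Nc2ccc(Br)cc2)n1`: > 50000 nM

All three compounds were tested in a functional assay on HL-60 cells (Homo sapiens), read by calcium flux (on this read-out lower numbers stand for an effect already at smaller amounts and higher numbers for an effect only at larger amounts of compound), and each value is a limit of the assay, not a number. The picture is simple: the limit of > 50000 nM in this assay, at which 3 of the 3 values shown sit. Compound 2 therefore has no measured potency, only its limit.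

Compound 4 `COc1ccc(Nc2cc(C)nn(CC(=O)Nc3ccc(Br)cc3)c2=O)cc1` has not yet been measured. It carries (4-methoxyphenyl)amino in place of (furan-3-yl)methyl on an aromatic carbon.

Among the compounds with values here, three measured steps bear on this change: a step that the two limits leave unreadable from compound 1 to compound 2, a step that the two limits leave unreadable from compound 2 to compound 3 and a step that the two limits leave unreadable from compound 1 to compound 3. None has a readable size, and none introduces the entering group, so they supply no expected size. The most likely outcome in this assay is therefore another limit, and any number would be expected toward smaller amounts. For compound 4 the expected step is an at least 1.6-fold lower number from compound 2 to compound 4 (0.22 log units; that floor lies within the scatter). For compound 4 the estimated value is 30000 nM, with an expected range of 3000 nM to 50000 nM.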

Compound 4, half-maximal effective concentration: > 50000 nM
Compound 4 gave a limit, no number; the forecaster's own chance of this, stated with the estimate: 60%; middle value at least 1.6-fold (0.22 log units) from the limit.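

In this assay, within the data shown here, compound 4 gives > 50000 nM, a limit and not a number, so no step between compound 2 and compound 4 can be read. The compounds shown leave open whether any change to the shared core would give a measurable value, and how large it would be: the limit of > 50000 nM in this assay, at which 4 of the 4 values shown sit.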